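The compounds below may be only part of what the source reports. "The series", "measured", "known", "first", "only" and "open" are said of these compounds alone.

Compound 1, `CC(C)n1ncc2c(C(=O)NCc3cn(-c4ccc(I)cc4)nn3)cccc21`: in a functional assay on MCF7 cells (Homo sapiens) for inhibition, read by MTT assay, with a stated time of 72 h (a higher number here means a weaker inhibitor, a lower number a stronger inhibitor), compound 1 gives > 40000 nM, which is a limit of the assay and not a number.
Compound 2, `CC(C)n1ncc2c(C(=O)NCc3cn(-c4ccc([N+](=O)[O-])cc4)nn3)cccc21`: in this assay compound 2 gives > 40000 nM, again a limit.
Compound 3, `CC(C)n1ncc2c(C(=O)NCc3cn(-c4ccccc4F)nn3)cccc21`: in this assay compound 3 gives > 40000 nM, also a limit.

Going by the values given here, compound 3 therefore stands where every measured compound stands, at the limit of > 40000 nM in this assay, at which 3 of the 3 values shown sit; no readable number exists for any of the three, and so no compound can be ranked against another.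

The step to compound 4, `CC(C)n1ncc2c(C(=O)NCc3cn(-c4ccc(C(F)(F)F)cc4)nn3)cccc21`, changes the group on the aromatic nitrogen of the five-membered ring: 4-(trifluoromethyl)phenyl in place of 2-fluorophenyl on an aromatic nitrogen. Among the compounds with values here, three measured steps touch the same position. The step from compound 1 to compound 2 is a step that the two limits leave unreadable from compound 1 to compound 2, the step from compound 1 to compound 3 is a step that the two limits leave unreadable from compound 1 to compound 3, and the step from compound 2 to compound 3 is a step that the two limits leave unreadable from compound 2 to compound 3. None of them gives a size, so the change of the aryl group at this position has, so far, never moved a value off the limit, and no direction for the new step can be read from them.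

Compound 4 is therefore expected to give 50000 nM in this assay, within a range of 20000 nM to 150000 nM, most likely once more reported only as a limit. The expected step from compound 3 to compound 4 is a step that the limit leaves unreadable from compound 3 to compound 4, that is, nothing beyond the scatter.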

Compound 4, half-maximal inhibitory concentration: > 40000 nM
Compound 4: a limit, no number; the forecaster's own chance of this, stated with the estimate: 85%; the middle value lies beyond the limit too.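

The steps linking compound 4 to compound 1, compound 2 and compound 3 cannot be read, because all four compounds give a limit of the assay and not a number: the limit of > 40000 nM in this assay, at which 4 of the 4 values shown sit.

The compounds shown leave open how strong any of the four really is in this assay, and whether any group on that aromatic nitrogen can bring a value off the limit.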